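Replacing a linking methyl on the triazole nitrogen

The compounds below may be only part of what the source reports. "The series", "measured", "known", "first", "only" and "open" are said of these compounds alone.

Measured compounds:
compound 1, `CN(CCNCc1cn(-c2cccc(Cl)c2)nn1)CCNc1ccnc2cc(Cl)ccc12`, 12000 nM
compound 2, `CN(CCNCc1cn(C(C)(C)C)nn1)CCNc1ccnc2cc(Cl)ccc12`, 39000 nM
compound 3, `CN(CCNCc1cn(Cc2nc3cc(Cl)ccc3[nH]2)nn1)CCNc1ccnc2cc(Cl)ccc12`, 44000 nM

All three share the same core and differ only in the group on an aromatic nitrogen of the triazole ring. In a functional assay on BXPC-3 cells (Homo sapiens) for antiproliferative activity, read by sulforhodamine B assay, with a stated time of 72 h (on this read-out lower numbers stand for stronger inhibition and higher numbers for weaker inhibition), compound 3 gives the highest of the three numbers; its step to compound 2, a 1.1-fold higher number from compound 2 to compound 3 (0.05 log units; within the scatter), lies within the scatter, while its step from compound 1, a 3.7-fold higher number from compound 1 to compound 3 (0.56 log units; beyond the scatter), lies beyond it.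

Compound 4, `CN(CCNCc1cn(-c2nc3ccccc3[nH]2)nn1)CCNc1ccnc2cc(Cl)ccc12`, is not yet measured. It differs from compound 3 in one place: 1H-benzimidazol-2-yl in place of (5-chloro-1H-benzimidazol-2-yl)methyl on an aromatic nitrogen. The group that enters is a benzimidazole without the chlorine and without the methyl link through which the group of compound 3 is attached.

Going by the values given here, two measured steps bear on this. Compound 1, whose 3-chlorophenyl sits on the aromatic nitrogen without a methyl link, gives the lowest number, and a 3.7-fold higher number from compound 1 to compound 3 (0.56 log units; beyond the scatter) shows the change to a linked benzimidazole raising the number. The step of a 1.1-fold higher number from compound 2 to compound 3 (0.05 log units; within the scatter) shows that swapping two linked or bulky groups changes little. Compound 4 resembles compound 1 in attaching a ring to the nitrogen with no link, so a modest move toward lower numbers is expected, a 2.4-fold lower number from compound 3 to compound 4 (0.39 log units; beyond the scatter). The estimate for compound 4 in this assay is 18000 nM, expected between 6000 nM and 55000 nM.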

Compound 4, half-maximal inhibitory concentration: 16000 nM
Beside the measured number, compound 4's estimate is 1.1-fold (0.05 log units) above it; the range from low to high includes it.
By their numbers in this assay, from the lowest: compounds 1 and 4 (each within the scatter of the next); then compounds 2 and 3 (each within the scatter of the next).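

In this assay, putting 1H-benzimidazol-2-yl in place of (5-chloro-1H-benzimidazol-2-yl)methyl on this aromatic nitrogen gives a 2.8-fold lower number from compound 3 to compound 4 (0.44 log units; beyond the scatter), so a benzimidazole at this position does not by itself bring the high number seen before. The same entering group, set against tert-butyl, gives a 2.4-fold lower number from compound 2 to compound 4 (0.39 log units; beyond the scatter), while against 3-chlorophenyl it gives a 1.3-fold higher number from compound 1 to compound 4 (0.12 log units; within the scatter), so these two aromatic groups, one with a single ring and one with two, cannot be told apart at this position. Among these four compounds, compound 1 and compound 4 carry an aromatic ring on the nitrogen with no methyl link and form the lower pair, but compound 2 also lacks a methyl link and sits in the higher pair with compound 3, so the missing link alone does not account for the split.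

Nothing measured here explains these differences. From the compounds shown here alone, the chlorine and the methyl link leave together, so their separate shares cannot be read, and the effect of an amine or a carboxylic acid on the benzimidazole, or of a longer chain in place of the methyl link, remains open.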